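Allylsulfanyl in Place of Methylsulfanyl: An Expected Outcome

This account rests on a few compounds, and the source may have more. Where it says the series, first, only, none or still open, it means among the compounds named here.

Compound 1 `COCc1ncc2cnnc(SC)n12` is one of three compounds already tested in a functional assay for inhibition, with Homo sapiens as the target; on this read-out higher numbers stand for weaker inhibition and lower numbers for stronger inhibition. In this assay compound 1 returns only a limit, > 48000 nM. Compound 2 `C=CCSc1nncc2c(CC)ncn12` likewise returns only a limit in this assay, > 48000 nM. Compound 3 `CCCc1nc(C)c2c(C)nn(CCC)c(=O)n12` also returns only a limit in this assay, > 48000 nM. Going by the values given here, all three values sit at the limit of > 48000 nM in this assay, at which 3 of the 3 values shown sit, so no step between measured compounds can be sized. Compound 4 `C=CCSc1nncc2cnc(COC)n12` has not yet been measured; it differs from compound 1 by vinyl in place of hydrogen on a saturated chain carbon bound to a sulfur. Compound 2 already carries the allylsulfanyl group, and in this assay compound 2 gives only the limit > 48000 nM. Compound 4 is therefore expected to give about 60000 nM in this assay, between 20000 nM and 200000 nM, most probably again as a limit. The expected step that the limit leaves unreadable from compound 1 to compound 4 is accordingly none beyond the scatter.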

Compound 4, half-maximal inhibitory concentration: 79000 nM
Compound 4: the middle estimate sits 1.3-fold (0.12 log units) below what was measured; measured number inside the range.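

In this assay, going by these compounds alone, compound 1 gives only a limit (> 48000 nM), so no step to compound 4 can be read. The compounds shown leave open how much allylsulfanyl in place of methylsulfanyl changes inhibition.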